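Replacing a Sulfanyl Group on a Shared Core

The source may report more compounds than this note shows. Statements on the series, on what has been measured and on what is new or still open speak of the compounds shown alone.

Measured so far in a functional assay on RAW264.7 cells (Mus musculus) for inhibition, with stated times of 2 h and 24 h (on this read-out lower numbers stand for stronger inhibition and higher numbers for weaker inhibition), are these compounds:
Compound 1 `COc1ccc([C@@H]2c3c(OC)cc(OC)cc3/C(=C/c3ccc(F)cc3)[C@H]2c2cc(OC)cc(OC)c2)cc1` gives > 200000 nM (a limit)
Compound 2 `COc1ccc(CSC2c3cc(OC)cc(OC)c3[C@@H](c3ccccc3)[C@@H]2c2cc(OC)cc(OC)c2)cc1` gives > 200000 nM (a limit)
Compound 3 `COc1ccc([C@@H]2c3c(OC)cc(OC)cc3C(SCc3ccc(C)cc3)[C@H]2c2cc(OC)cc(OC)c2)cc1` gives > 200000 nM (a limit)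

All three results are limits of the assay, not numbers. Compound 3 stands at the limit of > 200000 nM in this assay, at which 3 of the 3 values shown sit, with the others. Compound 4 `COc1ccc([C@@H]2c3c(OC)cc(OC)cc3C(C(O)c3ccccc3)[C@H]2c2cc(OC)cc(OC)c2)cc1` carries hydroxy(phenyl)methyl in place of (4-methylbenzyl)sulfanyl on a saturated ring carbon and is not yet measured. Within the data shown here, no pair differing in one place has been measured in this assay so the size of this step is uncertain. A small move toward stronger inhibition is expected, or none beyond the scatter. The expected change is an at least 1.3-fold lower number from compound 3 to compound 4 (0.12 log units; that floor lies within the scatter) on this estimate. The estimated value for compound 4 is 150000 nM with an expected range from 30000 nM to 250000 nM if a number is reported at all.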

Compound 4, half-maximal inhibitory concentration: > 200000 nM
Compound 4: only a limit was reported; the forecaster's own chance of this, stated with the estimate: 65%; middle value at least 1.3-fold (0.12 log units) from the limit.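

Compound 3 and compound 4 both give only a limit, so no step between them can be read: the limit of > 200000 nM in this assay, at which 4 of the 4 values shown sit.

The compounds shown leave open whether hydroxy(phenyl)methyl and (4-methylbenzyl)sulfanyl differ at all, and whether any compound on this shared core gives a measurable inhibition.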